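The compounds below may be only part of what the source reports. "The series", "measured", "known", "first", "only" and "open" are said of these compounds alone.

Three compounds have been measured in an in vitro assay on 293-EBNA cells for binding affinity to corticotropin-releasing factor receptor 1 (Homo sapiens); a higher number here means a weaker inhibitor, a lower number a stronger inhibitor:

Compound 1 `Cc1nc(N2CCCCC2)c2nnn(-c3ccc(C(C)C)cc3Br)c2n1`: 46 nM
Compound 2 `CCCC(CCC)Nc1nc(C)nc2c1nnn2-c1c(C)cc(C)cc1C`: 4 nM
Compound 3 `CCCCN(CC)c1nc(C)nc2c1nnn2-c1c(Cl)cc(OC)cc1OC`: 4.4 nM

Among these three, compound 1 stands at the highest number, so it is the weakest inhibitor of the set. Its nearest neighbour is compound 3, whose number is lower by a margin beyond the usual scatter; compound 2 lies furthest from it, with a still lower number, again beyond the scatter. Compounds 2 and 3 both carry an open-chain amino group on the shared core, whereas compound 1 carries a ring there.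

Compound 4 `CCC(CO)Nc1nc(C)nc2c1nnn2-c1ccc(C(C)C)cc1Br` keeps the aryl group of compound 1 and changes only that position: (1-(hydroxymethyl)propyl)amino in place of piperidin-1-yl on an aromatic carbon. Among the measured compounds shown here, no pair differing in a single place has been measured, so the size of this step is not known. For the measured compounds named here, on the two open-chain amino compounds, compound 2 at 4 nM and compound 3 at 4.4 nM, a move towards a lower number seems the more likely direction, though the new group also brings hydroxyl and amine hydrogens that none of the measured compounds has.

Compound 4 is therefore expected to fall at about 15 nM, with a plausible range from 4 nM to 60 nM, an estimated step of a 3.1-fold lower number from compound 1 to compound 4 (0.49 log units; beyond the scatter).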

Compound 4, inhibition constant: 25.3 nM
Compound 4: the middle estimate sits 1.7-fold (0.23 log units) below what was measured; the measured number falls inside the stated range.
By their numbers in this assay, from the lowest: compounds 2 and 3 (each within the scatter of the next); then compounds 4 and 1 (each within the scatter of the next).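

In this assay, placing (1-(hydroxymethyl)propyl)amino instead of piperidin-1-yl on this aromatic carbon of the shared core gives a 1.8-fold lower number from compound 1 to compound 4 (0.26 log units; within the scatter), so the two groups cannot be told apart in this measurement. Among the compounds shown here, this is the first single-place comparison at this position: with the aryl group held constant, an open chain with two hydrogen-bond donors reads the same, within the scatter, as a six-membered non-aromatic ring with none. That is a useful finding in its own right, since a sizeable swap of one group for another of equal heavy-atom count leaves no clear mark on the number, and no measurement at hand accounts for this outcome.

As far as these compounds go, it remains open whether the hydroxyl contributes anything, which a 1-methylpropylamino group, the same chain without its oxygen, or a methoxymethyl version of it could test on the same aryl group. From the compounds shown here alone, it is also open how a ring carrying a second hetero atom, such as morpholin-4-yl, or the dipropyl-type branched chain of compound 2 would read when paired with the aryl group of compound 1.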